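The source may report more compounds than this note shows. Statements on the series, on what has been measured and on what is new or still open speak of the compounds shown alone.

Working notes on the series. Within the data shown here, compound 1 `Cc1nc(Nc2ccc(Cl)cc2)sc1C(=O)/C=C/c1ccccc1` holds the only number so far in a functional assay on PC-3 cells (Homo sapiens) for cytotoxicity, read by MTT assay; on this read-out lower numbers stand for stronger inhibition and higher numbers for weaker inhibition: in this assay compound 1 gives 24600 nM. Compound 2 `COc1cccc(/C=C/C(=O)c2sc(Nc3ccc(Cl)cc3)nc2C)c1` returns no number; in this assay compound 2 gives > 25000 nM, which is a limit of the assay. Among the measured compounds shown here, the single measured step, an at least 1.0-fold higher number from compound 1 to compound 2 (0.00 log units; that floor lies within the scatter), methoxy in place of hydrogen on an aromatic carbon, is therefore bounded by the limit of > 25000 nM in this assay, at which 1 of the 2 values shown sits, and carries no direction of its own.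

Compound 3 `Cc1nc(Nc2ccc(Cl)c(Cl)c2)sc1C(=O)/C=C/c1ccccc1` differs from compound 1 by chloro in place of hydrogen on an aromatic carbon. For the measured compounds named here, no measured step touches this ring or this group, so the one step on record bears on it only in that a change on the other aromatic ring did not move the number beyond the scatter. A step of about the same size is expected, a 1.2-fold lower number from compound 1 to compound 3 (0.09 log units; within the scatter), that is none beyond the scatter. Compound 3 is estimated at 20000 nM, within 7000 nM to 60000 nM.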

Compound 3, half-maximal inhibitory concentration: 7990 nM
Compound 3: middle estimate off by 2.5-fold (0.40 log units), on the high side, and the stated range covers the measured number.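

Going from 4-chlorophenyl to 3,4-dichlorophenyl gives the first step in the series that lies beyond the scatter in this assay: a 3.1-fold lower number from compound 1 to compound 3 (0.49 log units; beyond the scatter). The change shows that this carbon, on the ring already carrying a chloro group, accepts a second chloro group and that the number moves lower, although the step is modest and rests on a single pair. Compound 2 remains a limit and not a number, and its methoxy step cannot be read against this one: the limit of > 25000 nM in this assay, at which 1 of the 3 values shown sits.

Only chloro is shown at this carbon, and it stays open whether the lower number is particular to chloro or would also appear with fluoro, trifluoromethyl or an amine there. Also open, going by these compounds, is whether a chloro group on the other aromatic ring would produce a similar step.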